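Stereocentre inversion at the ring ester carbon of compound 3

The source may hold more compounds than are shown below. What is called first, only, known or untested is meant among the compounds shown, and "the series" means these compounds.

Of the compounds shown here, three have been measured in an assay on HEK293-A cells with probable G-protein coupled receptor 34 (Mus musculus) as the target, with a stated time of 1.5 h; a higher number here means a larger maximal response, a lower number a smaller maximal response. Compound 1 `N[C@@H](COP(=O)(O)O[C@@H]1C=CCO[C@@H]1COC(=O)CCc1ccccc1OCc1cccc(Oc2ccccc2)c1)C(=O)O` gives 0.2 in this assay. Compound 2 `CCCCCCCCCCCOc1ccccc1CCC(=O)OC[C@H]1OCC=C[C@H]1OP(=O)(O)OC[C@H](N)C(=O)O` gives 0.086 in this assay. Compound 3 `N[C@@H](COP(=O)(O)OC[C@H]1OCC=C[C@H]1OC(=O)CCc1ccccc1OCc1cccc(Oc2ccccc2)c1)C(=O)O` gives 0.86 in this assay, the highest of the three numbers; its gap to compound 1 and its gap to compound 2 are each beyond the scatter of repeated measurements.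

Compound 4 `N[C@@H](COP(=O)(O)OC[C@H]1OCC=C[C@@H]1OC(=O)CCc1ccccc1OCc1cccc(Oc2ccccc2)c1)C(=O)O` has not yet been measured. It differs from compound 3 as follows: the two compounds have the same atoms and bonds; at least one stereo element is drawn with a configuration in one of them and without one in the other: 1 of 4 stereo elements differ; a stereocentre at a saturated ring carbon is drawn R in compound 3 and S in compound 4. Among the compounds with values here, no pair of measured compounds in this set is related by that kind of change, so the size of the step is not set by any number at hand; the only guidance is that compound 3 stands highest with 0.86, leaving more room to fall than to rise.

The expectation is that compound 4 gives 0.55 in this assay, with a range from 0.2 to 0.9. Within the data shown here, this expected value corresponds to a step of a number 0.31 lower from compound 3 to compound 4 (beyond the scatter), a downward step that may or may not exceed the scatter, given how little can be inferred from the compounds measured so far.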

Compound 4, intrinsic activity: the largest response reached, as a fraction of the reference agonist's: "not active" (no number reported)
Nothing numeric was reported for compound 4, and the estimate cannot be compared.
By their numbers in this assay, from the lowest: compound 2; then compound 1; then compound 3.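

In this assay, within the data shown here, compound 3 gives 0.86, while compound 4 is reported as not active, without a number, so no step between compound 3 and compound 4 can be read. The compounds shown leave open how large a change this stereocentre brings, and the pair carries one caveat: the fact that one of compounds 3 and 4 is drawn with a defined configuration and the other without, at the place where they differ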